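Replacing the benzylic amide amine with a piperidine ring

This account rests on a few compounds, and the source may have more. Where it says the series, first, only, none or still open, it means among the compounds named here.

Compound 2 `COc1ccc(OC)c(-c2cc(-c3ccc(C(=O)N(C)Cc4ccc(F)cc4)s3)on2)c1` was tested in a functional assay on PC-3 cells (Homo sapiens) for cytotoxicity, read by XTT assay, with a stated time of 72 h; on this read-out higher numbers stand for weaker inhibition and lower numbers for stronger inhibition. In this assay compound 2 gives only a limit, > 30000 nM. The related compound 1 `COc1ccc(OC)c(-c2cc(-c3ccc(C(=O)N4CCCC4)s3)on2)c1` carries pyrrolidin-1-yl on the same carbonyl carbon; in this assay compound 1 likewise gives only a limit, > 30000 nM. The step that the two limits leave unreadable from compound 1 to compound 2 cannot be read as a result. Compound 3 `COc1ccc(OC)c(-c2cc(-c3ccc(C(=O)N4CCCCC4)s3)on2)c1` has not yet been measured and differs from compound 2 by piperidin-1-yl in place of (4-fluorobenzyl)(methyl)amino on a carbonyl carbon. Within the data shown here, the one change of the same kind is the one from compound 1 to compound 2, whose size the two limits conceal; what is known is the limit of > 30000 nM in this assay, at which 2 of the 2 values shown sit. With both neighbours sitting at that limit, no step beyond the scatter is expected in this assay, and the step that the limit leaves unreadable from compound 2 to compound 3 is an estimate rather than a reading. Compound 3 is accordingly expected to show about 50000 nM, within a range from 15000 nM to 200000 nM, most probably again reported only as a limit.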

Compound 3, half-maximal inhibitory concentration: > 30000 nM
Compound 3 was reported as a limit (the forecaster's own chance of this, stated with the estimate: 85%); the middle value is on the limit's open side.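

In this assay compound 3 gives > 30000 nM, which is a limit and not a number. The steps among compound 1, compound 2 and compound 3 therefore cannot be read: the limit of > 30000 nM in this assay, at which 3 of the 3 values shown sit. The compounds shown leave open how far apart these three amides truly lie, and whether any group on this carbonyl carbon gives a measurable value.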